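The compounds below may be only part of what the source reports. "The series", "measured", "known", "first", "only" and "open" are said of these compounds alone.

Working notes on the series. In an assay on HeLa cells for displacement of a labelled ligand from adenosine receptor A3 (Homo sapiens), read by scintillation counting, with a stated time of 180 min, tested at 10 uM (a lower number here means less inhibition, a higher number more inhibition at the concentration tested (going by the name of the read-out)), compound 2 `COc1cccc2cc(C(=O)NC3CCCCC3)c(=N)oc12` gives 16% and compound 1 `COc1cccc2cc(C(=O)NCCO)c(=N)oc12` gives 23%; the step of a number 7 percentage points lower from compound 1 to compound 2 (within the scatter) stays within the scatter, so the two numbers are not told apart. Compound 3 `COc1cccc2cc(C(=O)NC(CO)(CO)CO)c(=N)oc12` differs from compound 2 by 2-hydroxy-1,1-bis(hydroxymethyl)ethyl in place of cyclohexyl on an amide-type nitrogen. Going by the values given here, the only measured step, from 2-hydroxyethyl to cyclohexyl on the same amide-type nitrogen, was small, so no change beyond the scatter is expected here either, and a step of a number 4 percentage points higher from compound 2 to compound 3 (within the scatter) is estimated. Compound 3 is therefore expected to give about 20%, in the range 5% to 38%.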

Compound 3, a percentage reported as inhibition, at one concentration (the size of the read-out at that concentration, not a potency): 18%
For compound 3 the middle estimate is 2 percentage points above the measured one, and the stated range covers the measured number.
By their numbers in this assay, from the lowest: compounds 2, 3 and 1 (each within the scatter of the next).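

In this assay 2-hydroxy-1,1-bis(hydroxymethyl)ethyl on the amide-type nitrogen gives a number 2 percentage points higher from compound 2 to compound 3 (within the scatter) and a number 5 percentage points lower from compound 1 to compound 3 (within the scatter) with neither step beyond the scatter. At this position, a group with no ring and 3 hydrogen-bond donors therefore cannot be told apart from cyclohexyl, which has 0 hydrogen-bond donors, or from 2-hydroxyethyl. No measurement offers an explanation for this result. Going by these compounds, what an aminoethyl chain or a carboxylic acid on this nitrogen would give remains open, as does the effect of any change to the shared core.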